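A few compounds are considered here, and "the series" means these few. Any claim that something is new, unique, unknown or untested is made for them only; others in the source may bear on it.

Within the data shown here, in a functional assay on MDA-MB-231 cells (Homo sapiens) for inhibition, read by CellTiter-Glo, with a stated time of 72 h (on this read-out lower numbers stand for higher toxicity in this test and higher numbers for lower toxicity in this test), compound 1 `CC1=C(CC(=O)NCCN(C)C)c2cc(F)ccc2/C1=C\c1ccncc1` gives 18100 nM, the lower of the two numbers so far, and compound 2 `CC1=C(CC(=O)NCCN(C)C)c2cc(F)ccc2/C1=C\c1ccc(S(C)(=O)=O)cc1` gives 37500 nM. Among the measured compounds shown here, the only measured step is a 2.1-fold higher number from compound 1 to compound 2 (0.32 log units; beyond the scatter). It is modest and comes from 4-(methylsulfonyl)phenyl in place of pyridin-4-yl on a double-bonded chain carbon bound to a double-bonded ring carbon.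

Compound 3 `CC1=C(CC(=O)NCCN2CCCC2)c2cc(F)ccc2/C1=C\c1ccncc1` carries a different change from compound 1: pyrrolidin-1-yl in place of dimethylamino on a saturated chain carbon, two bonds along the chain from an amide-type nitrogen. In words, this is pyrrolidin-1-yl in place of dimethylamino on a saturated chain carbon, two bonds along the chain from an amide-type nitrogen. For the measured compounds named here, no measured step covers this place, so the step to compound 2 offers only a rough sense of scale and no direction.

The expected result in this assay is no shift beyond the scatter, with the estimated step being a 1.1-fold lower number from compound 1 to compound 3 (0.05 log units; within the scatter). For compound 3 the estimated value is 16000 nM, with an expected range of 8000 nM to 32000 nM.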

Compound 3, half-maximal cytotoxic concentration: 7190 nM
Compound 3: middle estimate off by 2.2-fold (0.35 log units), on the high side; the whole stated range lies above it.
By their numbers in this assay, from the lowest: compound 3; then compound 1; then compound 2.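

In this assay, the place on a saturated chain carbon, two bonds along the chain from an amide-type nitrogen, proves responsive: pyrrolidin-1-yl in place of dimethylamino gives a 2.5-fold lower number from compound 1 to compound 3 (0.40 log units; beyond the scatter), a change that points to higher toxicity in this test. Among these compounds, the first measured change at this place is therefore beyond the scatter, as is the earlier change on the double-bonded chain carbon, so both sites now register on this read-out. The swap replaces an open dimethylamino group with one five-membered non-aromatic ring, but no measurement explains the shift.

From the compounds shown here alone, it remains open whether piperidin-1-yl, morpholin-4-yl or a longer chain ending in an amine would extend this trend. Whether the step holds with 4-(methylsulfonyl)phenyl in place of pyridin-4-yl is also unresolved.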